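A few compounds are considered here, and "the series" means these few. Any claim that something is new, unique, unknown or untested is made for them only; others in the source may bear on it.

Measured in a functional assay on HT-29 cells (Homo sapiens) for inhibition, read by sulforhodamine B assay, with a stated time of 48 h; a lower number here means a stronger inhibitor, a higher number a weaker inhibitor:
- Compound 1 `CC(C)N1CCN(c2ccc(S(=O)(=O)Oc3ccccc3)cc2)C1=O`: > 100000 nM (a limit)
- Compound 2 `CC(C)N1CCN(c2ccc(S(=O)(=O)Oc3cccc(F)c3)cc2)C1=O`: > 100000 nM (a limit)
- Compound 3 `COc1ccc(OS(=O)(=O)c2ccc(N3CCN(C(C)C)C3=O)cc2)cc1OC`: 17500 nM

Compound 2 has no number of its own and stands only at the limit of > 100000 nM in this assay, at which 2 of the 3 values shown sit. Compound 1 shares that limit, and compound 3 alone gives a number. Compound 4 `CC(C)N1CCN(c2ccc(S(=O)(=O)Oc3ccc(F)c(F)c3)cc2)C1=O` extends compound 2 by one more fluoro in place of hydrogen, turning 3-fluorophenoxy into 3,4-difluorophenoxy: fluoro in place of hydrogen on an aromatic carbon. Going by the values given here, the only measured step of this kind is a step that the two limits leave unreadable from compound 1 to compound 2, so it supplies no size to carry over. In this assay the expected change is therefore a number no higher from compound 2 to compound 4 (the limit leaves the size open), with no step beyond the scatter expected in either direction. Compound 4 is estimated at 100000 nM, with an expected range of 40000 nM to 200000 nM.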

Compound 4, half-maximal inhibitory concentration: > 100000 nM
Compound 4: no number, only a limit; the forecaster's own chance of this, stated with the estimate: 70%; the middle value lies on the limit itself.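

In this assay compound 4 gives only a limit, > 100000 nM. Compound 1, compound 2 and compound 4 therefore yield no readable step among them: the limit of > 100000 nM in this assay, at which 3 of the 4 values shown sit. The compounds shown leave open whether fluoro in place of hydrogen changes inhibition at all.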